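This account rests on a few compounds, and the source may have more. Where it says the series, first, only, none or still open, it means among the compounds named here.

- compound 1 `O=S(=O)(Nc1cc(F)cc(Cl)c1)c1ccc(-c2cnc(C3CC3)o2)cc1` gives 1440 nM
- compound 2 `Cc1ccc(Cl)c(NS(=O)(=O)c2ccc(-c3cnc(C4CC4)o3)cc2)c1` gives 48.8 nM

In a functional assay on cells (leukaemia cell line, Homo sapiens) for inhibition, read by sulforhodamine B assay, with a stated time of 48 h (a higher number here means a weaker inhibitor of growth, a lower number a stronger inhibitor of growth), compound 2 has the lower of the two numbers, making it the stronger inhibitor of growth. For the measured compounds named here, the only measured step is a 30-fold lower number from compound 1 to compound 2 (1.47 log units; beyond the scatter), so changing this group can matter greatly. Compound 3 `O=S(=O)(Nc1ccc(I)c(Cl)c1)c1ccc(-c2cnc(C3CC3)o2)cc1` differs from compound 2 as follows: 3-chloro-4-iodophenyl in place of 2-chloro-5-methylphenyl on a sulfonamide nitrogen. Compound 1, which also lacks the 2-chloro-5-methylphenyl group, gives 1440 nM, so a higher number is expected, though one step cannot fix its size. The expected change is an 8.2-fold higher number from compound 2 to compound 3 (0.91 log units; beyond the scatter). For compound 3 the estimate is 400 nM, with an expected range from 70 nM to 2300 nM.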

Compound 3, concentration for 50% growth inhibition: 1010 nM
For compound 3 the middle estimate is 2.5-fold (0.40 log units) below the measured one; the measured number falls inside the stated range.
By their numbers in this assay, from the lowest: compound 2; then compounds 3 and 1 (each within the scatter of the next).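

In this assay, a second replacement of the 2-chloro-5-methylphenyl group on the sulfonamide nitrogen also gives a large loss of growth inhibition (a 21-fold higher number from compound 2 to compound 3 (1.32 log units; beyond the scatter)). The two replacement groups, 3-chloro-4-iodophenyl and 3-chloro-5-fluorophenyl, cannot be told apart (a 1.4-fold lower number from compound 1 to compound 3 (0.15 log units; within the scatter)), so among these three compounds only the 2-chloro-5-methylphenyl group stands apart. Nothing measured here explains this difference. Still open, on these data alone, is whether the chlorine, the methyl or their arrangement on the ring matters most, and whether a methoxy or an amine group on this ring could match compound 2.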